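Amide-end swap on compound 2: cycloheptylamino to pyrrolidinyl

The source may hold more compounds than are shown below. What is called first, only, known or untested is meant among the compounds shown, and "the series" means these compounds.

Compound 2 `CC(C)=CCC/C(C)=C/CC/C(C)=C/CSC[C@H](NC(=O)CCCCCN1CCCC1)C(=O)NC1CCCCCC1` gives 4.93 in a physicochemical assay for lipophilicity (on this read-out higher numbers stand for higher lipophilicity and lower numbers for lower lipophilicity), the lowest of the three numbers measured. Compound 1 `CC(C)=CCC/C(C)=C/CC/C(C)=C/CSC[C@H](NC(=O)CCCCCN1CCN(C)CC1)C(=O)NC1CCCCCC1` gives 5.44, and compound 3 `CC(C)=CCC/C(C)=C/CC/C(C)=C/CSc1ccccc1C(N)=O` gives 6.03. Going by the values given here, the only single-point step within the measured set is a number 0.51 log units lower from compound 1 to compound 2 (beyond the scatter), a change on the saturated chain carbon five bonds along the chain from a carbonyl carbon, not at the amide end.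

Compound 4 `CC(C)=CCC/C(C)=C/CC/C(C)=C/CSC[C@H](NC(=O)CCCCCN1CCCC1)C(=O)N1CCCC1` differs from compound 2 by pyrrolidin-1-yl in place of cycloheptylamino on a carbonyl carbon. Among the compounds with values here, no measured pair shows this change or any change at the cycloheptylcarbamoyl end, so a number 0.51 log units lower from compound 1 to compound 2 (beyond the scatter) informs only the general scale of steps, not their direction here. The group entering is smaller by three heavy atoms and drops the one hydrogen-bond donor, so a step lower of moderate size is expected, a number 0.93 log units lower from compound 2 to compound 4 (beyond the scatter). Compound 4 is therefore expected to give 4 in this assay, with a range of 3.4 to 4.6.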

Compound 4, distribution coefficient: 3.31
Compound 4: the middle estimate sits 0.69 log units above what was measured, outside the stated range (below it).
By their numbers in this assay, from the lowest: compound 4; then compound 2; then compound 1; then compound 3.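

Going by these compounds alone, the carbonyl-carbon position, which no earlier pair touched, proves strongly responsive: in this assay, the exchange gives a number 1.62 log units lower from compound 2 to compound 4 (beyond the scatter), a large step, whereas the only earlier step is the modest a number 0.51 log units lower from compound 1 to compound 2 (beyond the scatter), made on a saturated chain carbon. The change of cycloheptylamino to pyrrolidin-1-yl therefore moves this read-out substantially, and compound 4 now stands lowest of the four compounds. This single exchange changes the ring, the heavy-atom count and the hydrogen-bond donor count together, so the step belongs to the whole replacement and not to any one of these differences.

Cyclopentylamino and azepan-1-yl on the same carbonyl carbon would help to separate ring size from loss of the amide hydrogen. No supporting evidence accounts for the size of this step.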